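Removing the anilide: does the free acid stay inactive?

A few compounds are considered here, and "the series" means these few. Any claim that something is new, unique, unknown or untested is made for them only; others in the source may bear on it.

Compound 1 `C=CC1=C(C(=O)Nc2ccc(C)cc2)C(c2ccc(F)cc2)OC1` carries a (4-methylphenyl)amino group on its carbonyl carbon. In a functional assay on A549 cells (Homo sapiens) for cytotoxicity, read by MTT assay, with a stated time of 24 h (on this read-out lower numbers stand for stronger inhibition and higher numbers for weaker inhibition), compound 1 reaches only > 100000 nM, a limit of the assay and not a number. Compound 2 `C=CC1=C(C(=O)NCc2ccccc2F)C(c2ccc(F)cc2)OC1` likewise sits at the limit > 100000 nM in this assay. Compound 3 `C=CC1=C(C(=O)Nc2ccc(C)cc2)C(c2ccc(OC)cc2)OC1` also gives only the limit > 100000 nM in this assay. The steps a step that the two limits leave unreadable from compound 1 to compound 2 and a step that the two limits leave unreadable from compound 1 to compound 3 cannot be sized because the limit of > 100000 nM in this assay, at which 3 of the 3 values shown sit, holds all three values. Compound 4 `C=CC1=C(C(=O)O)C(c2ccc(F)cc2)OC1` differs from compound 1 by hydroxy in place of (4-methylphenyl)amino on a carbonyl carbon. Among the compounds with values here, no measured step bears on this change. With every value at the limit, compound 4 is expected to give 150000 nM (between 50000 nM and 500000 nM) in this assay. The expected step that the limit leaves unreadable from compound 1 to compound 4 would thus most likely again be unreadable against the limit.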

Compound 4, half-maximal inhibitory concentration: > 100000 nM
Compound 4 was reported as a limit; the forecaster's own chance of this, stated with the estimate: 85%; the middle value does not contradict the limit.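

No size can be read for the change from compound 1 to compound 4, because both sit at a limit of the assay and not at a number: the limit of > 100000 nM in this assay, at which 4 of the 4 values shown sit. The compounds shown leave open which change to the shared core, if any, would give a measurable value in this assay.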